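The compounds below may be only part of what the source reports. "The series", "measured", "known", "first", "only" and "open" are said of these compounds alone.

Working notes on the series.

The shared core of compound 1 `O=C(Nc1ccc(Oc2ccnc3[nH]ccc23)cc1)c1ccc(-c2ccc(Cl)cc2)cn1` carries an amide-linked pyridine with a pendant aryl ring. In a functional assay on A549 cells (Homo sapiens) for cytotoxicity, read by MTT assay, with a stated time of 72 h (on this read-out higher numbers stand for weaker inhibition and lower numbers for stronger inhibition), compound 1 gives a limit of the assay, > 10000 nM. Compound 2 `Cc1cccc(-c2ccnc(C(=O)Nc3ccc(Oc4ccnc5[nH]ccc45)cc3)c2)c1` carries a 3-methylphenyl and in this assay compound 2 gives 7010 nM. Compound 3 `Cc1cccc(-c2ccnc(C(=O)Nc3ccc(Oc4ccnc5[nH]ccc45)c(F)c3)c2)c1` adds a fluoro in place of hydrogen on an aromatic carbon of the anilide ring; in this assay compound 3 gives 1750 nM, the lowest of the two numbers shown, with a 4.0-fold lower number from compound 2 to compound 3 (0.60 log units; beyond the scatter). Of the three values shown, one sits at the limit (the limit of > 10000 nM in this assay, at which 1 of the 3 values shown sits).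

Compound 4 `O=C(Nc1ccc(Oc2ccnc3[nH]ccc23)c(F)c1)c1cc(-c2ccc(F)cc2)ccn1` differs from compound 3 by 4-fluorophenyl in place of 3-methylphenyl on an aromatic carbon. No measured step touches this exchange: the only step shown, from compound 2 to compound 3, concerns the anilide fluoro and is kept in compound 4. Compound 1 carries a halogenated phenyl on a differently substituted pyridine and gives only a limit, so it offers no number to compare. The step of a 1.7-fold higher number from compound 3 to compound 4 (0.23 log units; within the scatter) is therefore expected to be small and uncertain in direction, and compound 4 is estimated at 3000 nM, within 900 nM to 12000 nM, in this assay.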

Compound 4, half-maximal inhibitory concentration: 1090 nM
Beside the measured number, compound 4's estimate is 2.8-fold (0.44 log units) above it; the measured number falls inside the stated range.
By their numbers in this assay, from the lowest: compounds 4 and 3 (each within the scatter of the next); then compound 2. At a limit, above all of these: compound 1.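

On the aromatic carbon opposite the ring nitrogen, with the anilide fluoro kept in place, 4-fluorophenyl in place of 3-methylphenyl gives a 1.6-fold lower number from compound 3 to compound 4 (0.21 log units; within the scatter) in this assay, so the two aryl groups cannot be told apart at this position. Going by these compounds alone, the earlier compounds gave a numerical step only at the anilide fluoro, and this is the first step that can be read at the aryl group itself, where a methyl-bearing ring and a fluorine-bearing ring give values within the scatter of each other. No measurement shown accounts for this result.

From the compounds shown here alone, what an amine or a carboxylic acid on this aryl ring would give in this assay remains open, as does the effect of a saturated ring such as morpholine in place of the aryl ring. It also remains open whether the anilide fluoro step, a 4.0-fold lower number from compound 2 to compound 3 (0.60 log units; beyond the scatter), carries over to the 4-fluorophenyl compounds, as that step is shown only with 3-methylphenyl.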